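Fluoro on the pendant phenyl of compound 2: tolerance notes

A few compounds are considered here, and "the series" means these few. Any claim that something is new, unique, unknown or untested is made for them only; others in the source may bear on it.

Compound 2, `COc1ccc(-c2cc3cc(-c4ccccc4)cc(C(C)=O)c3[nH]2)cc1`, and compound 1, `CC(=O)c1cc(-c2ccc(F)cc2)cc2cc(-c3ccccc3)[nH]c12`, form the measured part of this series. In a functional assay on MCF7 cells (Homo sapiens) for cytotoxicity, read by MTT assay, with a stated time of 2 days (a higher number here means that more compound is tolerated, a lower number that less compound is tolerated), compound 2 gives only a limit of the assay, > 100000 nM. Compound 1 likewise gives only a limit, > 100000 nM. Both cases fall under (the limit of > 100000 nM in this assay, at which 2 of the 2 values shown sit), so nothing separates them. Compound 3, `COc1ccc(-c2cc3cc(-c4ccc(F)cc4)cc(C(C)=O)c3[nH]2)cc1`, differs from compound 2 in one place: fluoro in place of hydrogen on an aromatic carbon. Going by the values given here, no measured step of this kind exists. The step that the limit leaves unreadable from compound 2 to compound 3 is expected to stay within the usual scatter, in neither direction. Compound 3 is therefore estimated at 150000 nM, between 50000 nM and 500000 nM, most probably again only a limit.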

Compound 3, concentration lethal to 50% of the cells: > 100000 nM
Compound 3 gave a limit, no number (the forecaster's own chance of this, stated with the estimate: 85%); the middle value lies beyond the limit too.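

Going by these compounds alone, no step among compound 1, compound 2 and compound 3 can be read, as each gives only a limit: the limit of > 100000 nM in this assay, at which 3 of the 3 values shown sit. Going by these compounds, whether fluoro or methoxy in place of hydrogen shifts the tolerated concentration in either direction stays open.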